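The source may hold more compounds than are shown below. What is called first, only, known or untested is meant among the compounds shown, and "the series" means these compounds.

Measured compounds:
Compound 1, `COc1ccc(-c2cccc(COc3ccc([C@H](CC(=O)O)c4nccn4C)cc3)c2)cc1`, gives 440 nM in an assay on CHO cells for agonist activity at Free fatty acid receptor 1 (Homo sapiens), read by luminescence, with a stated time of 20 s, in the presence of a further agent that is not named here; on this read-out lower numbers stand for an effect already at smaller amounts and higher numbers for an effect only at larger amounts of compound.
Compound 2, `Cc1c(Cl)cccc1-c1cccc(COc2ccc([C@H](CC(=O)O)c3nccn3C)cc2)c1`, gives 61 nM.
Compound 3, `CCc1ccccc1-c1cccc(COc2ccc([C@H](CC(=O)O)c3nccn3C)cc2)c1`, gives 48 nM.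

Compound 3 shows the lowest number of the three, though its gap to compound 2 is within the scatter; only the gap to compound 1, a 9.2-fold lower number from compound 1 to compound 3 (0.96 log units; beyond the scatter), is beyond it. Compound 4, `Cn1ccnc1[C@@H](CC(=O)O)c1ccc(OCc2cccc(-c3ccccc3S(C)(=O)=O)c2)cc1`, differs from compound 3 by methylsulfonyl in place of ethyl on an aromatic carbon. The measured steps all concern the same position on that ring, a 7.2-fold lower number from compound 1 to compound 2 (0.86 log units; beyond the scatter) and a 1.3-fold lower number from compound 2 to compound 3 (0.10 log units; within the scatter), but none brings in a methylsulfonyl or any group with hydrogen-bond acceptors, so they bear on it only loosely. With groups that sit on that carbon having stayed close to one another, the estimate for compound 4 is a 1.9-fold higher number from compound 3 to compound 4 (0.27 log units; within the scatter), a small step at most. The expected value of compound 4 is 90 nM, within 25 nM to 350 nM.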

Compound 4, half-maximal effective concentration: 23000 nM
Estimate against measurement, compound 4: 260-fold (2.41 log units) below, outside the stated range (above it).
By their numbers in this assay, from the lowest: compounds 3 and 2 (each within the scatter of the next); then compound 1; then compound 4.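

Methylsulfonyl in place of ethyl on this aromatic carbon, ortho to a large group, gives a 480-fold higher number from compound 3 to compound 4 (2.68 log units; beyond the scatter) and so shows that this position does not accept every group, which the earlier changes there could not show. The loss also stands against the other two rings, with a 380-fold higher number from compound 2 to compound 4 (2.58 log units; beyond the scatter) and a 52-fold higher number from compound 1 to compound 4 (1.72 log units; beyond the scatter), so compound 4 lies well past even compound 1. Nothing shown here accounts for this loss.

The compounds shown leave open how a methyl sulfoxide, a methoxy or an amine on that same carbon would read, and so whether the loss belongs to methylsulfonyl alone.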